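The source may hold more compounds than are shown below. What is called first, only, known or untested is meant among the compounds shown, and "the series" means these compounds.

Compound 1 `CC1=C(C(=O)Nc2ccc([N+](=O)[O-])cc2)C(c2ccc(Br)cc2)N=C(SCc2ccc(Cl)cc2)N1`: 6.2%
Compound 2 `CC1=C(C(=O)Nc2ccc([N+](=O)[O-])cc2)C(c2cccc([N+](=O)[O-])c2)N=C(SCc2ccccc2)N1`: 4.1%
Compound 3 `CC1=C(C(=O)Nc2ccc([N+](=O)[O-])cc2)C(c2cccc([N+](=O)[O-])c2)N=C(SCc2ccccc2Cl)N1`: 3.6%

In a functional assay on the whole organism (artery, strain albino) with Rattus norvegicus as the target, with a stated time of 30 min, at a dose of 10 mg/kg by the oral route (on this read-out lower numbers stand for less inhibition and higher numbers for more inhibition at the one dose given (going by the name of the read-out)), compound 3 gives 3.6%. Its reading lies within the usual scatter of the reading of compound 2 and of compound 1, so the three measured compounds are not separated on this read-out. Compound 4 `CC1=C(C(=O)Nc2ccc([N+](=O)[O-])cc2)C(c2cccc([N+](=O)[O-])c2)N=C(SCc2ccc(Cl)cc2)N1` has not yet been measured. It differs from compound 3 in one place: 4-chlorophenyl in place of 2-chlorophenyl on a saturated chain carbon bound to a sulfur. Among the measured compounds shown here, the only measured step that touches this part of the molecule is a number 0.5 percentage points lower from compound 2 to compound 3 (within the scatter), a change that stayed within the scatter. For the measured compounds named here, no measured pair differs solely in the position of the chlorine on the benzyl group; compound 1, which carries the 4-chlorobenzyl group together with a different group on the core, gives 6.2%, again within the scatter of compound 3. On these numbers no step beyond the scatter is expected for a number 0.9 percentage points higher from compound 3 to compound 4 (within the scatter). Compound 4 is therefore estimated at 4.5%, between 0% and 12%.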

Compound 4, a percentage reported as inhibition, in the whole organism at one dose (the size of the read-out at that dose, not a potency): 3.1%
Compound 4: the middle estimate sits 1.4 percentage points above what was measured, within the range that was stated.
By their numbers in this assay, from the lowest: compounds 4, 3, 2 and 1 (each within the scatter of the next).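

In this assay, among the compounds shown here, the move from 2-chlorobenzyl to 4-chlorobenzyl is the first direct reading of the chlorine's position on this group, and it gives a number 0.5 percentage points lower from compound 3 to compound 4 (within the scatter) and so does not separate the two placements. Set against the unsubstituted benzyl group, the 4-chlorobenzyl group gives a number 1 percentage points lower from compound 2 to compound 4 (within the scatter), so a chlorine at either printed position leaves the reading within the scatter of the compound without it. With the 4-chlorobenzyl group held constant, the change on the saturated ring carbon gives a number 3.1 percentage points lower from compound 1 to compound 4 (within the scatter), and nothing at hand bears on why these readings lie so close together. As far as these compounds go, whether an amine or a carboxylic acid on the benzyl group would move the reading beyond the scatter stays open. So does the effect of a longer chain in place of the benzyl group on sulfur.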